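The source may hold more compounds than are shown below. What is called first, only, known or untested is meant among the compounds shown, and "the series" means these compounds.

Within the data shown here, compound 1 `CC[C@@H]1C(=O)N(C)c2cnc(-n3ccc4cc(F)ccc43)nc2N1C1CCCC1` is one of three compounds measured in a functional assay on Huh-7 cells (Homo sapiens) for antiproliferative activity, read by CCK-8 assay, with a stated time of 72 h; on this read-out higher numbers stand for weaker inhibition of growth and lower numbers for stronger inhibition of growth. Compound 1 gives 16000 nM, the highest of the three numbers. Compound 3 `CCCNS(=O)(=O)c1ccc(Nc2ncc3c(n2)N(c2ccn(C)n2)C(CC)C(=O)N3C)cc1` gives 8880 nM in this assay, which lies within the usual scatter of the number for compound 1. Compound 2 `CCC1C(=O)N(C)c2cnc(-n3ccc4cc(C(=O)NCC(C)C)ccc43)nc2N1c1ccn(C)n1` gives 5070 nM in this assay, and its gap to compound 1 lies beyond the scatter. Compound 4 `CC[C@@H]1C(=O)N(C)c2cnc(-n3ccc4cc(C(=O)NCC(C)C)ccc43)nc2N1C1CCCC1` has not yet been measured in this assay. It differs from compound 1 in one place: isobutylcarbamoyl in place of fluoro on an aromatic carbon. Among the measured compounds shown here, no pair of measured compounds isolates this change. Compound 2 carries the same isobutylcarbamoyl group and gives 5070 nM in this assay. On that basis a moderate downward step is expected for compound 4, a 2.7-fold lower number from compound 1 to compound 4 (0.43 log units; beyond the scatter). Compound 4 is expected to give 6000 nM in this assay, within a range of 2000 nM to 18000 nM.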

Compound 4, concentration for 50% growth inhibition: "not active" (no number reported)
No number was reported for compound 4; no gap can be computed for the estimate.
By their numbers in this assay, from the lowest: compounds 2, 3 and 1 (each within the scatter of the next, the first and the last beyond it).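

In this assay, among these compounds, compound 4 is reported as not active, without a number, so no step from compound 1 can be read. The compounds shown leave open what isobutylcarbamoyl in place of fluoro alone does to growth inhibition. No measurement here accounts for this result.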